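The source may report more compounds than this note shows. Statements on the series, on what has been measured and on what is new or still open speak of the compounds shown alone.

Measured compounds:
compound 1, `Brc1ccc(OC[C@@H]2CCN2)cn1`, 0.021 nM
compound 2, `Fc1ccc(OC[C@H]2CCN2)cn1`, 0.066 nM

Of the compounds shown here, two have been measured in an assay on brain for binding affinity to Neuronal acetylcholine receptor; alpha4/beta2 (Rattus norvegicus), read by radioligand binding; a higher number here means a weaker inhibitor, a lower number a stronger inhibitor. Compound 1 gives 0.021 nM, and compound 2 gives 0.066 nM. Compound 2 therefore stands with the higher of the two numbers; the value of compound 1 lies lower, and that gap is beyond the scatter of repeated measurements. Compounds 1 and 2 differ in more than one place, so no single step can be read between them; only their two values are known.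

Compound 3, `Brc1ccc(OC[C@H]2CCN2)cn1`, has not yet been measured. It comes from compound 2 by one change: bromo in place of fluoro on an aromatic carbon. For the measured compounds named here, no step of this kind has been measured among the compounds here, so the size of the step can only be estimated. Given that compound 1, which also carries bromo, gives 0.021 nM, a modest step toward a lower number is expected for compound 3, of the order a 1.7-fold lower number from compound 2 to compound 3 (0.22 log units; within the scatter), though it may well stay within the scatter. The expected value of compound 3 in this assay is 0.04 nM, with a range from 0.015 nM to 0.11 nM.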

Compound 3, inhibition constant: 0.17 nM
Estimate against measurement, compound 3: 4.3-fold (0.63 log units) below, and the stated range ends below it.
By their numbers in this assay, from the lowest: compound 1; then compound 2; then compound 3.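

In this assay, the aromatic carbon next to the ring nitrogen proves sensitive to the halogen it carries: with the stereocentre drawn as in compound 2, bromo in place of fluoro gives a 2.6-fold higher number from compound 2 to compound 3 (0.41 log units; beyond the scatter), so on this configuration the fluoro compound has the lower number. The earlier pair could not show this, since compounds 1 and 2 differ in more than one place and their gap could not be assigned to either the halogen or the stereocentre. Compound 3 now separates the two changes, and the larger of the two steps, an 8.1-fold higher number from compound 1 to compound 3 (0.91 log units; beyond the scatter), can be assigned to the stereocentre at the saturated ring carbon alone, which is drawn S in compound 1 and R in compound 3: the fact that compounds 1 and 3 differ only in the configuration as drawn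

The compounds shown leave open whether bromo and fluoro would rank the same way with the stereocentre drawn S, since only bromo is present in that configuration. They also leave open how this aromatic carbon would respond to chloro, to a methyl group or to an amine, and whether such a group would keep a number as low as that of either halogen.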